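This account rests on a few compounds, and the source may have more. Where it says the series, first, only, none or still open, it means among the compounds named here.

Compound 1 `NC(=O)c1nn(C2O[C@H](CO)[C@@H](O)[C@H]2O)cc1[N+](=O)[O-]` gives a limit, > 1730 uM, in a functional assay on Vero cells (Chlorocebus sabaeus); on this read-out higher numbers stand for weaker inhibition and lower numbers for stronger inhibition.
Compound 2 `Cc1c([N+](=O)[O-])c(C(N)=O)nn1C1O[C@H](CO)[C@@H](O)[C@H]1O` gives a limit, > 1650 uM, in this assay.
Compound 3 `Cc1nn(C2O[C@H](CO)[C@@H](O)[C@H]2O)c2c1N=NN(Cc1ccccc1)C2O` gives a limit, > 1340 uM, in this assay.

Compound 1 therefore stands at a limit, not at a number, as do the other two: the limit of > 1730 uM in this assay, at which 1 of the 3 values shown sits, the limit of > 1650 uM in this assay, at which 1 of the 3 values shown sits, and (the limit of > 1340 uM in this assay, at which 1 of the 3 values shown sits). Among the measured compounds shown here, the one single-point step, a step that the two limits leave unreadable from compound 1 to compound 2, is unreadable. Compound 4 `NC(=O)c1nn(C2O[C@H](CO)[C@@H](O)[C@H]2O)cc1N` differs from compound 1 by amino in place of nitro on an aromatic carbon. For the measured compounds named here, no measured step reads this change, and every value shown is a limit. The expected step of an at least 1.0-fold lower number from compound 1 to compound 4 (0.00 log units; that floor lies within the scatter) is therefore none beyond the scatter. Compound 4 is estimated at 1700 uM in this assay, within 400 uM to 6000 uM, most likely again reported as a limit.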

Compound 4, concentration for 50% inhibition: > 1830 uM
Compound 4: no number, only a limit; the forecaster's own chance of this, stated with the estimate: 85%; middle value at least 1.0-fold (0.03 log units) from the limit.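

Compound 1 and compound 4 both give only limits in this assay, so the step between them cannot be read. The compounds shown leave open what amino in place of nitro does, and whether any of them reaches a measurable number.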